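This account rests on a few compounds, and the source may have more. Where it says the series, first, only, none or still open, it means among the compounds named here.

Compounds measured:
- compound 1, `COc1nc2ccc(Br)cc2cc1C(c1ccccc1)n1cc(-c2ccc(Br)cc2)nn1`, gives 6.92%
- compound 2, `CCCCCCc1cn(C(c2ccccc2)c2cc3cc(Br)ccc3nc2OC)nn1`, gives -0.97%
- compound 3, `COc1nc2ccc(Br)cc2cc1C(c1ccccc1)n1cc(-c2ccccc2)nn1`, gives 13.9%

These three numbers come from an ADME assay on HeLa cells (Homo sapiens) for cytotoxicity, read by sulforhodamine B assay, with a stated time of 48 h, tested at 10 uM; on this read-out higher numbers stand for more inhibition at the one concentration tested (going by the name of the read-out) and lower numbers for less inhibition. Compound 3 stands highest of the three, but its gap to compound 1 lies within the scatter, a number 7 percentage points higher from compound 1 to compound 3 (within the scatter), so only its gap to compound 2 counts, a number 14.9 percentage points higher from compound 2 to compound 3 (beyond the scatter). Compound 4, `CCCCc1cn(C(c2ccccc2)c2cc3cc(Br)ccc3nc2OC)nn1`, has not yet been measured. It differs from compound 3 in one place: butyl in place of phenyl on an aromatic carbon. The step that bears on this is the one where a chain gave way to a ring, a number 14.9 percentage points higher from compound 2 to compound 3 (beyond the scatter), a modest rise; read backwards, a chain in place of the ring points to a modest fall. The step of a number 7.9 percentage points lower from compound 1 to compound 2 (within the scatter) stayed within the scatter. For compound 4, a drop of about a number 9.9 percentage points lower from compound 3 to compound 4 (within the scatter) in this assay is therefore expected, landing near 4%, within the range -8% to 16%.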

Compound 4, a percentage reported as inhibition, at one concentration (the size of the read-out at that concentration, not a potency): -2.87%
The estimate for compound 4 lay 6.9 percentage points above the measured number; the measured number falls inside the stated range.
By their numbers in this assay, from the lowest: compounds 4, 2, 1 and 3 (each within the scatter of the next, the first and the last beyond it).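

In this assay, a second chain on this aromatic carbon also falls clearly short of phenyl (a number 16.8 percentage points lower from compound 3 to compound 4 (beyond the scatter)), so the earlier gap between hexyl and phenyl was not a quirk of hexyl alone. Shortening hexyl to butyl makes no difference beyond the scatter (a number 1.9 percentage points lower from compound 2 to compound 4 (within the scatter)), and butyl cannot be told apart from 4-bromophenyl (a number 9.8 percentage points lower from compound 1 to compound 4 (within the scatter)). No measurement here explains why phenyl differs from the chains. Going by these compounds, whether a methyl group, an amine or a carboxylic acid on this carbon would change the number remains open.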